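Working notes: from compound 3 to compound 4

The source may hold more compounds than are shown below. What is called first, only, known or untested is meant among the compounds shown, and "the series" means these compounds.

Values in an ADME assay on MCF7 cells (Homo sapiens) for cytotoxicity, with a stated time of 72 h (on this read-out higher numbers stand for weaker inhibition and lower numbers for stronger inhibition), are as follows:
- Compound 1 `Oc1cccc(CNc2ncnc3c2ncn3C2CCCCO2)c1` gives > 100000 nM as a limit
- Compound 2 `Oc1cc(O)cc(CNc2ncnc3c2ncn3C2CCCCO2)c1` gives > 100000 nM as a limit
- Compound 3 `Oc1cccc(CNc2ncnc3c2ncn3C2CCCO2)c1` gives > 100000 nM as a limit

Compound 3 stands at > 100000 nM and this is a limit, not a number. For the measured compounds named here, the series so far shows the limit of > 100000 nM in this assay, at which 3 of the 3 values shown sit, and offers no readable number.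

Compound 4 `COc1ccc(CNc2ncnc3c2ncn3C2CCCO2)cc1` differs from compound 3 as follows: 4-methoxyphenyl in place of 3-hydroxyphenyl on a saturated chain carbon bound to a nitrogen on an aromatic ring. In short, 4-methoxyphenyl stands in place of 3-hydroxyphenyl on a saturated chain carbon bound to a nitrogen on an aromatic ring.

Going by the values given here, two measured steps bear on this only loosely. One is a step that the two limits leave unreadable from compound 1 to compound 2 with hydroxy in place of hydrogen on an aromatic carbon. The other is a step that the two limits leave unreadable from compound 1 to compound 3 with oxolan-2-yl in place of oxan-2-yl on an aromatic nitrogen. Neither has a size to carry over, so no step beyond the scatter is expected in this assay and no direction can be assigned. The expected step is a number no higher from compound 3 to compound 4 (the limit leaves the size open) as an estimate only. Compound 4 is estimated at 100000 nM with 30000 nM to 200000 nM as the expected range.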

Compound 4, half-maximal inhibitory concentration: > 100000 nM
Compound 4: a limit, no number; the forecaster's own chance of this, stated with the estimate: 80%; the middle value sits exactly at the limit.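

Compound 4 gives > 100000 nM as a limit and not a number, so no step can be read from compound 3 to compound 4. The compounds shown leave open the size and direction of every change among them, as all values sit at one limit: the limit of > 100000 nM in this assay, at which 4 of the 4 values shown sit.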